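Replacing Methylcarbamoyl by 2-Aminophenyl on a Spiro Sulfone Amide

A few compounds are considered here, and "the series" means these few. Any claim that something is new, unique, unknown or untested is made for them only; others in the source may bear on it.

As far as these compounds go, the study concerns three measured compounds and one still open. Compound 1 `COc1ccc(Oc2ccc(S(=O)(=O)C3(C(=O)Nc4ccccc4N)CCC4(CCNCC4)C3)cc2Cl)cc1`, compound 2 `CNC(=O)NC(=O)C1(S(=O)(=O)c2ccc(Oc3ccc(OC)cc3)c(Cl)c2)CCC2(CCNCC2)C1` and compound 3 `CCCN1CCC2(CC1)CCC(C(=O)NC(=O)NC)(S(=O)(=O)c1ccc(Oc3ccc(OC(F)(F)F)cc3)cc1)C2` were tested in a functional assay on blood (Homo sapiens), with a stated time of 60 min, in the presence of a further agent that is not named here; on this read-out higher numbers stand for an effect only at larger amounts of compound and lower numbers for an effect already at smaller amounts. Compound 2 gives 3700 nM in this assay. For compound 1 only a limit of the assay is recorded, > 15000 nM. For compound 3 likewise only a limit of the assay is recorded, > 15000 nM.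

Compound 1 and compound 2 differ in one place: 2-aminophenyl in place of methylcarbamoyl on an amide-type nitrogen. This change gave an at least 4.0-fold higher number from compound 2 to compound 1 (0.60 log units; beyond the scatter). That the step is stated only as a lower bound follows from the limit of > 15000 nM in this assay, at which 2 of the 3 values shown sit, since the value of compound 1 is one of the two that rest at that limit.

Compound 4 `CCCN1CCC2(CC1)CCC(C(=O)Nc1ccccc1N)(S(=O)(=O)c1ccc(Oc3ccc(OC(F)(F)F)cc3)cc1)C2` has not yet been measured. It stands to compound 3 as compound 1 stands to compound 2: 2-aminophenyl in place of methylcarbamoyl on an amide-type nitrogen. The place lines of the two changes read the same, so this is the same change made on a different core; the difference between the core of compound 2 and the core of compound 3 is not broken down here.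

Since compound 3 already sits at a limit of the assay and the same change weakened compound 2 to compound 1 by an at least 4.0-fold higher number from compound 2 to compound 1 (0.60 log units; beyond the scatter), compound 4 is expected to stay at or beyond that limit, a step of roughly a step that the limit leaves unreadable from compound 3 to compound 4. The estimate for compound 4 in this assay is 30000 nM, most likely reported again only as a limit.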

Compound 4, half-maximal effective concentration: <= 400 nM
Compound 4 gave a limit, no number; the forecaster's own chance of this, stated with the estimate: 85%; at least 75-fold (1.87 log units) between middle value and limit.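

In this assay, putting 2-aminophenyl in place of methylcarbamoyl on the amide-type nitrogen of the core of compound 3 gave an at least 37-fold lower number from compound 3 to compound 4 (1.57 log units; beyond the scatter), whereas the same change on the core of compound 2 moved the number the other way, so the two steps disagree in direction as well as in size: the same change on two cores in this assay, an at least 4.0-fold higher number (0.60 log units; beyond the scatter) from compound 2 to compound 1 and an at least 37-fold lower number (1.57 log units; beyond the scatter) from compound 3 to compound 4, at least 150-fold (2.18 log units) apart, beyond the scatter of two such steps

Compound 4 gives <= 400 nM, which is a limit of the assay and not a number. This shows that, in this series, the outcome of the change on one core cannot be carried over to another, but it does not show how large either step really is, since both are known only as bounds, nor does it show which feature of the cores goes with the difference, since the core of compound 2 and the core of compound 3 differ in more than one place.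

The compounds shown leave open whether the propyl chain, the chlorine or the trifluoromethoxy group goes with the reversal. Also open, as far as these compounds go, is how a plain phenyl or a 2-hydroxyphenyl group on the same amide-type nitrogen would read in this assay on either core.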